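A Mirror-Image Centre in the Most Soluble Compound

A few compounds are considered here, and "the series" means these few. Any claim that something is new, unique, unknown or untested is made for them only; others in the source may bear on it.

Compound 3 `CC(=O)NC[C@H]1CN(c2ccc(OC[C@@H](O)CNC3CC3)c(F)c2)C(=O)O1` has the highest solubility of the three compounds measured: in a physicochemical assay for solubility, read by HPLC (a higher number here means a more soluble compound, a lower number a less soluble compound), compound 3 gives 96000000 nM, while compound 2 `CC(=O)NC[C@H]1CN(c2ccc(OC[C@H](O)CNc3ccncc3)c(F)c2)C(=O)O1` gives 24600000 nM and compound 1 `COc1ccc(NC[C@@H](O)COc2ccc(N3C[C@H](CNC(C)=O)OC3=O)cc2F)cc1` gives 1300 nM. Compound 4 `CC(=O)NC[C@H]1CN(c2ccc(OC[C@H](O)CNC3CC3)c(F)c2)C(=O)O1` differs from compound 3 only in configuration: the two compounds have the same atoms and bonds and differ only in configuration as drawn: 1 of 2 stereo elements differ; a stereocentre at a saturated chain carbon is drawn S in compound 3 and R in compound 4. The measured steps changed groups rather than configuration: a 19000-fold higher number from compound 1 to compound 2 (4.28 log units; beyond the scatter) was large, and a 3.9-fold higher number from compound 2 to compound 3 (0.59 log units; beyond the scatter) was modest. For the measured compounds named here, neither bears directly on the inversion of a single stereocentre, and no measured pair shows such an inversion, so no change beyond the scatter is expected. Compound 4 is therefore expected to give an estimated 90000000 nM, with a range from 35000000 nM to 200000000 nM, which means an expected step of a 1.1-fold lower number from compound 3 to compound 4 (0.03 log units; within the scatter).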

Compound 4, solubility: 2200000 nM
Estimate against measurement, compound 4: 41-fold (1.61 log units) above; measured number outside the range, below it.
By their numbers in this assay, from the lowest: compound 1; then compound 4; then compound 2; then compound 3.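

Configuration at this saturated chain carbon matters by itself in this assay, with a 44-fold lower number from compound 3 to compound 4 (1.64 log units; beyond the scatter). That step belongs to the stereocentre alone because nothing else in the structures changes: the fact that compounds 3 and 4 differ only in the configuration as drawn

Among the groups on the amine nitrogen, cyclopropyl in place of pyridin-4-yl gives an 11-fold lower number from compound 2 to compound 4 (1.05 log units; beyond the scatter), while cyclopropyl in place of 4-methoxyphenyl gives a 1700-fold higher number from compound 1 to compound 4 (3.23 log units; beyond the scatter).

Going by these compounds, whether the same inversion matters as much with pyridin-4-yl or 4-methoxyphenyl on that nitrogen stays open. So does whether an isopropyl or cyclobutyl group there would show a similar gap between the two configurations.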